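The source may hold more compounds than are shown below. What is called first, only, known or untested is meant among the compounds shown, and "the series" means these compounds.

Compound 1 `COC(=O)C1=C(C)N=C(C)/C(=C(\O)OC)C1c1ccccc1N`: 39800 nM
Compound 2 `CCOc1ccccc1C1C(C(=O)OC)=C(C)N=C(C)/C1=C(\O)OC`: 110 nM
Compound 3 `COC(=O)C1=C(C)N=C(C)/C(=C(\O)OC)C1c1cccc(Cl)c1Cl`: 19.1 nM

In a functional assay (muscle tissue) with Cavia porcellus as the target (on this read-out higher numbers stand for an effect only at larger amounts of compound and lower numbers for an effect already at smaller amounts), compound 3 has the lowest of the three numbers. Compound 4 `C=Cc1ccccc1C1C(C(=O)OC)=C(C)N=C(C)/C1=C(\O)OC` differs from it as follows: 2-vinylphenyl in place of 2,3-dichlorophenyl on a saturated ring carbon. Within the data shown here, two measured steps bear on this change. They are a 360-fold lower number from compound 1 to compound 2 (2.56 log units; beyond the scatter), with ethoxy in place of amino, and a 2100-fold lower number from compound 1 to compound 3 (3.32 log units; beyond the scatter), with 2,3-dichlorophenyl in place of 2-aminophenyl. Both are large, and both remove the amino group, which compound 4 also lacks. No large return towards compound 1 is therefore expected in this assay, but a modest rise is. The expected change is a 3.1-fold higher number from compound 3 to compound 4 (0.50 log units; beyond the scatter). The estimate for compound 4 is 60 nM, within a range of 15 nM to 250 nM.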

Compound 4, half-maximal effective concentration: 4.47 nM
For compound 4 the middle estimate is 13-fold (1.13 log units) above the measured one; the measured number lies below the stated range.
By their numbers in this assay, from the lowest: compound 4; then compound 3; then compound 2; then compound 1.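

In this assay the aryl group on the saturated ring carbon needs neither chlorine nor ethoxy: the all-carbon 2-vinylphenyl gives a 4.3-fold lower number from compound 3 to compound 4 (0.63 log units; beyond the scatter) and, against ethoxy, a 25-fold lower number from compound 2 to compound 4 (1.39 log units; beyond the scatter). Vinyl in place of amino gives an 8900-fold lower number from compound 1 to compound 4 (3.95 log units; beyond the scatter), the largest step in the series so far. Nothing available explains these differences.

Going by these compounds, whether the double bond itself matters stays open, since an ethyl group on the same aromatic carbon would separate it from the carbon chain. An allyl group would show whether a longer chain holds this level.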